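Lengthening the chain-end amine on two related cores

This account rests on a few compounds, and the source may have more. Where it says the series, first, only, none or still open, it means among the compounds named here.

Compound 1 `CN(C)CCCCn1c(N)c(-c2nc3ccccc3o2)c2nc(C#N)c(C#N)nc21` and compound 2 `CCN(CC)CCCCn1c(N)c(-c2nc3ccccc3o2)c2nc(C#N)c(C#N)nc21` share one core and differ only at the end of the chain that hangs from an aromatic nitrogen, a change counted as diethylamino in place of dimethylamino on a saturated chain carbon, four bonds along the chain from an aromatic nitrogen. In a functional assay on cells (Homo sapiens) for antiproliferative activity, read by MTT assay, with a stated time of 48 h (on this read-out higher numbers stand for weaker inhibition and lower numbers for stronger inhibition), compound 1 gives 6130 nM, and compound 2 gives 2710 nM. That single change therefore brought a 2.3-fold lower number from compound 1 to compound 2 (0.35 log units; beyond the scatter). Compound 3 `CN(C)CCCn1c(N)c(-c2nc3ccccc3n2C)c2nc(C#N)c(C#N)nc21` carries a different core; the difference between the two cores is not broken down here. In this assay compound 3 gives 3670 nM, a number within the scatter of both compound 1 and compound 2. Compound 4 `CCN(CC)CCCn1c(N)c(-c2nc3ccccc3n2C)c2nc(C#N)c(C#N)nc21` has not yet been measured. It relates to compound 3 as compound 2 relates to compound 1, the change being (diethylamino in place of dimethylamino on a saturated chain carbon, three bonds along the chain from an aromatic nitrogen). This is the same kind of change, not the same one, since here the amine sits three bonds along the chain from the aromatic nitrogen rather than four. Within the data shown here, the step for compound 4 is expected to be a 2.0-fold lower number from compound 3 to compound 4 (0.31 log units; beyond the scatter), resting on the one comparable pair. Compound 4 is estimated at 1800 nM, with a likely range from 900 nM to 4000 nM.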

Compound 4, half-maximal inhibitory concentration: 6750 nM
Beside the measured number, compound 4's estimate is 3.8-fold (0.57 log units) below it; measured number above the stated range.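

In this assay, swapping dimethylamino for diethylamino did not behave the same way on the two cores: the same change on two cores in this assay, a 2.3-fold lower number (0.35 log units; beyond the scatter) from compound 1 to compound 2 and a 1.8-fold higher number (0.26 log units; within the scatter) from compound 3 to compound 4, 4.2-fold (0.62 log units) apart, beyond the scatter of two such steps

On the core of compound 3, a 1.8-fold higher number from compound 3 to compound 4 (0.26 log units; within the scatter) is too small to count as a true reversal, so this pair shows no clear effect of the swap rather than an opposite one. Among these compounds, the result does not show that the core alone decides the outcome, since the amine sits four bonds along the chain from an aromatic nitrogen in compounds 1 and 2 but three bonds along it in compounds 3 and 4, and with only two pairs the core and the chain cannot be separated.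

Going by these compounds, it remains open what the same swap would do with the longer chain of compound 1 on the core of compound 3, a comparison that would pull those two factors apart. Also open, on these data alone, is how a ring amine such as piperidine at the chain end would compare with dimethylamino and diethylamino on either core.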